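The source may report more compounds than this note shows. Statements on the series, on what has been measured and on what is new or still open speak of the compounds shown alone.

Measured compounds in the series:

Compound 1 `CCC1(Cc2ccccc2)OS(=O)(=O)C=C1OCCCCc1ccccc1` — in an ADME assay on HEL cells (Homo sapiens) for cytotoxicity, with a stated time of 3 days (on this read-out lower numbers stand for higher toxicity in this test and higher numbers for lower toxicity in this test), compound 1 gives >= 20000 nM, a limit of the assay.
Compound 2 `CCC1(Cc2ccccc2)OS(=O)(=O)C=C1OCC(=O)OC` — in this assay compound 2 gives > 400000 nM, also a limit.
Compound 3 `CCC1(Cc2ccccc2)OS(=O)(=O)C=C1OCc1ccc(OC)cc1` — in this assay compound 3 gives >= 200000 nM, again a limit.

Within the data shown here, compound 3 therefore stands on a limit only, and the two other values shown are limits as well; no compound in this set has a read number. The steps a step that the two limits leave unreadable from compound 1 to compound 2, a step that the two limits leave unreadable from compound 1 to compound 3 and a step that the two limits leave unreadable from compound 2 to compound 3 are all unreadable for that reason: the three values sit at the limit of > 400000 nM in this assay, at which 1 of the 3 values shown sits, at the limit of >= 20000 nM in this assay, at which 1 of the 3 values shown sits, and at the limit of >= 200000 nM in this assay, at which 1 of the 3 values shown sits, and none of these ceilings can be compared with another as a true difference.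

Compound 4 `CCC1(Cc2ccccc2)OS(=O)(=O)C=C1OCc1ccc([N+](=O)[O-])cc1` is the next compound to be measured. Relative to compound 3 the change is nitro in place of methoxy on an aromatic carbon.

Among the measured compounds shown here, no measured step bears on this change in a readable way, since every step is blocked by a limit. The expectation is therefore the plainest one: compound 4 is estimated to stand close to compound 3, with the step of a number no higher from compound 3 to compound 4 (the limit leaves the size open) expected to be none beyond the scatter, and most likely the assay again returns a limit rather than a number. Compound 4 is estimated at 200000 nM, with a range from 50000 nM to 400000 nM.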

Compound 4, minimum cytotoxic concentration: >= 80000 nM
Compound 4: no number, only a limit; the forecaster's own chance of this, stated with the estimate: 75%; the middle value lies beyond the limit too.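

In this assay compound 4 gives >= 80000 nM, a limit of the assay. As far as these compounds go, none of its steps from compound 1, compound 2 or compound 3 can be read, and the size of the change from 4-methoxyphenyl to 4-nitrophenyl stays unknown. The compounds shown leave open whether any of these groups on the shared core shifts the minimum cytotoxic concentration at all: all four values are limits.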